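A few compounds are considered here, and "the series" means these few. Any claim that something is new, unique, unknown or untested is made for them only; others in the source may bear on it.

Compound 1 `O=C(/C=C/c1ccc2c(c1)B(O)OC2)c1ccccc1`: 2300 nM
Compound 2 `O=C(/C=C/c1ccc2c(c1)B(O)OC2)c1ccc(Cl)cc1`: 7900 nM
Compound 3 `CCc1ccc(C(=O)/C=C/c2ccc3c(c2)B(O)OC3)cc1`: 9800 nM

In a functional assay on MDA-MB-231 cells (Homo sapiens) for cytotoxicity, read by MTT assay, with a stated time of 48 h (on this read-out lower numbers stand for stronger inhibition and higher numbers for weaker inhibition), compound 1 stands lowest of the three numbers. Compound 2 and compound 3 both differ from it by a single substituent on an aromatic carbon of the benzoyl ring, and both steps move in the same direction: a 3.4-fold higher number from compound 1 to compound 2 (0.54 log units; beyond the scatter) and a 4.3-fold higher number from compound 1 to compound 3 (0.63 log units; beyond the scatter). Between these two substituted compounds the gap is small, a 1.2-fold higher number from compound 2 to compound 3 (0.09 log units; within the scatter), so on this evidence the two substituents are not told apart.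

Compound 4 `COc1cccc(C(=O)/C=C/c2ccc3c(c2)B(O)OC3)c1` is the next member of the series. Compared with compound 1 the change is methoxy in place of hydrogen on an aromatic carbon. Among the measured compounds shown here, no methoxy-bearing compound has been measured in this assay, and the substituted position differs from that in compound 2 and compound 3, so the two steps from compound 1 are the only guide. Both were modest rises, and a change of roughly that kind is expected here: a 2.2-fold higher number from compound 1 to compound 4 (0.34 log units; beyond the scatter). Compound 4 is therefore estimated at 5000 nM in this assay, with a range from 2000 nM to 13000 nM to allow for a step that may be smaller or absent.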

Compound 4, half-maximal inhibitory concentration: 2100 nM
Compound 4: the middle estimate sits 2.4-fold (0.38 log units) above what was measured, and the stated range covers the measured number.
By their numbers in this assay, from the lowest: compounds 4 and 1 (each within the scatter of the next); then compounds 2 and 3 (each within the scatter of the next).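

In this assay, methoxy in place of hydrogen on an aromatic carbon, meta to a large group, leaves the number unchanged within the scatter: a 1.1-fold lower number from compound 1 to compound 4 (0.04 log units; within the scatter). The earlier substitutions on this ring, which stand at a different place, both came with a rise, a 3.4-fold higher number from compound 1 to compound 2 (0.54 log units; beyond the scatter) and a 4.3-fold higher number from compound 1 to compound 3 (0.63 log units; beyond the scatter), so compound 4 shows that a substituent on this ring does not always bring a higher number, and that this position takes a methoxy group with no measurable change in this read-out. Nothing available here explains why this step stays flat while the other two do not.

Group and place change together between compound 4 and the chloro and ethyl compounds, so the compounds shown cannot tell whether the flat step belongs to the methoxy group, to its position, or to both. They also leave open whether a different group at this same position, such as an amine, a carboxylic acid or a longer chain, would likewise leave the number unchanged or would move it in either direction.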